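Removing the Indazole Methyl in a Diaryl Urea Series

The source may report more compounds than this note shows. Statements on the series, on what has been measured and on what is new or still open speak of the compounds shown alone.

Compound 1 `O=C(Nc1ccc(-n2ncc3c(Cl)cccc32)cc1)Nc1ccc(Cl)c(C(F)(F)F)c1`: 4600 nM
Compound 2 `Cc1cccc2c1cnn2-c1ccc(NC(=O)Nc2ccc(Cl)c(C(F)(F)F)c2)cc1`: 32000 nM

In a functional assay on HT-29 cells (Homo sapiens) for cytotoxicity, read by MTT assay, with a stated time of 72 h (a lower number here means a stronger inhibitor, a higher number a weaker inhibitor), compound 1 gives 4600 nM, while compound 2 gives 32000 nM. Compound 2 therefore stands at the highest of the two numbers, set apart from compound 1 by the step of a 7.0-fold higher number from compound 1 to compound 2 (0.84 log units; beyond the scatter). Compound 3 `O=C(Nc1ccc(-n2ncc3ccccc32)cc1)Nc1ccc(Cl)c(C(F)(F)F)c1` differs from compound 2 by hydrogen in place of methyl on an aromatic carbon; cut one bond further out, 4-methyl-1H-indazol-1-yl becomes 1H-indazol-1-yl. Among the compounds with values here, the only measured step that bears on this change is the one from compound 1 to compound 2, which shows a modest rise when methyl replaced chloro at this place. Within the data shown here, no compound with hydrogen there has been measured, so the direction is uncertain. Compound 3 is expected to fall between the two measured numbers, that is 12000 nM, within 4000 nM to 40000 nM. The estimated step is a 2.7-fold lower number from compound 2 to compound 3 (0.43 log units; beyond the scatter).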

Compound 3, half-maximal inhibitory concentration: 18200 nM
The estimate for compound 3 lay 1.5-fold (0.18 log units) below the measured number; the range from low to high includes it.
By their numbers in this assay, from the lowest: compound 1; then compounds 3 and 2 (each within the scatter of the next).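

In this assay, hydrogen in place of methyl gives a 1.8-fold lower number from compound 2 to compound 3 (0.25 log units; within the scatter) so at this position on the six-membered aromatic ring these two groups cannot be told apart. Hydrogen in place of chloro gives a 4.0-fold higher number from compound 1 to compound 3 (0.60 log units; beyond the scatter) and, with the earlier step from chloro to methyl, this leaves compound 1 as the one compound set apart, with compound 2 and compound 3 together at the higher numbers. No measurement shown explains why chloro differs from the other two groups.

From the compounds shown here alone, three groups at one position give no trend, so it remains open whether a fluoro, a bromo, a methoxy or an amine here would resemble chloro or fall with hydrogen and methyl. Going by these compounds, it also remains open whether the chloro result would hold with a different group in place of the chloro and trifluoromethyl pair on the far ring of the urea.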